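Fluoro in place of nitro: working notes on the series

The source may hold more compounds than are shown below. What is called first, only, known or untested is meant among the compounds shown, and "the series" means these compounds.

In an ADME assay on Vero cells (Chlorocebus sabaeus) for cytotoxicity, read by MTT assay, with a stated time of 72 h (on this read-out lower numbers stand for stronger inhibition and higher numbers for weaker inhibition), compound 3 `O=C(CCN1CCN(c2ccc([N+](=O)[O-])cc2)CC1)c1ccc(O)cc1` gives 34600 nM as the lowest of three numbers, with compound 1 `O=C(CCN1CCN(c2ccc(Cl)cc2)CC1)c1ccc(O)cc1` at 104000 nM and compound 2 `O=C(CCN1CCN(c2ccc(C(F)(F)F)cc2)CC1)c1ccc(O)cc1` at 107000 nM on the higher side. Compound 4 `O=C(CCN1CCN(c2ccc(F)cc2)CC1)c1ccc(O)cc1` carries fluoro in place of nitro on an aromatic carbon. Two modest steps at the same place end on nitro (a 3.0-fold lower number from compound 1 to compound 3 (0.48 log units; beyond the scatter)) and (a 3.1-fold lower number from compound 2 to compound 3 (0.49 log units; beyond the scatter)), while chloro and trifluoromethyl show no separation (a 1.0-fold higher number from compound 1 to compound 2 (0.01 log units; within the scatter)). Fluoro itself has not been measured, so leaving nitro is expected to give a similar modest rise in this assay and nothing larger. The expected step is a 2.5-fold higher number from compound 3 to compound 4 (0.39 log units; beyond the scatter) on this estimate. For compound 4 the estimated value is 85000 nM with an expected range of 38000 nM to 190000 nM in this series.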

Compound 4, half-maximal inhibitory concentration: 50000 nM
For compound 4 the middle estimate is 1.7-fold (0.23 log units) above the measured one, and the stated range covers the measured number.
By their numbers in this assay, from the lowest: compounds 3 and 4 (each within the scatter of the next); then compounds 1 and 2 (each within the scatter of the next).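

In this assay, fluoro and nitro on this aromatic carbon do not separate, a 1.4-fold higher number from compound 3 to compound 4 (0.16 log units; within the scatter), so nitro no longer stands alone at the low end. Fluoro does separate from trifluoromethyl, a 2.1-fold lower number from compound 2 to compound 4 (0.33 log units; beyond the scatter), and from chloro, a 2.1-fold lower number from compound 1 to compound 4 (0.32 log units; beyond the scatter), which divides the four compounds into two pairs: fluoro with nitro, and chloro with trifluoromethyl. Nothing available explains this pairing. On these data alone, whether an amine, a nitrile or a methoxy group on the same carbon would fall with either pair remains open, as does whether the pairing holds when the shared core changes.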